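This account rests on a few compounds, and the source may have more. Where it says the series, first, only, none or still open, it means among the compounds named here.

Compound 1 `CCOC(=O)c1oc2ccc(NS(=O)(=O)c3ccc(C(F)(F)F)cc3)cc2c1C` gives 5030 nM in a functional assay on HCT-116 cells (Homo sapiens) for inhibition, read by MTT assay, with a stated time of 72 h; on this read-out lower numbers stand for stronger inhibition and higher numbers for weaker inhibition.
Compound 2 `CCOC(=O)c1oc2ccc(N(Cc3ccccc3)S(=O)(=O)c3cccc(Br)c3)cc2c1C` gives only a limit in this assay, > 40000 nM.
Compound 3 `CCOC(=O)c1oc2ccc(N(Cc3ccccc3)S(=O)(=O)c3ccc(C)cc3)cc2c1C` likewise gives only a limit in this assay, > 40000 nM.

Compound 3 stands at the limit of this assay rather than at a measured number; the same is true of compound 2, so that the limit of > 40000 nM in this assay, at which 2 of the 3 values shown sit, describes where two of the three values sit, and only compound 1 has a readable value. The step from compound 2 to compound 3 is a step that the two limits leave unreadable from compound 2 to compound 3.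

Compound 4 `CCOC(=O)c1oc2ccc(N(Cc3ccccc3)S(=O)(=O)c3ccc(F)cc3)cc2c1C` differs from compound 3 by fluoro in place of methyl on an aromatic carbon. For the measured compounds named here, the only step that bears on it, from compound 2 to compound 3, cannot be read in size because both ends are limits, so no direction or size can be drawn from the measured compounds. Compound 4 is therefore expected to sit where compound 3 sits, at the limit of this assay, with the step from compound 3 to compound 4 estimated as a step that the limit leaves unreadable from compound 3 to compound 4. For compound 4 the estimate is 60000 nM, within a range from 20000 nM to 200000 nM.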

Compound 4, half-maximal inhibitory concentration: 5820 nM
Compound 4: the middle estimate sits 10-fold (1.01 log units) above what was measured, and the stated range ends above it.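

Swapping methyl for fluoro on this aromatic carbon, para to a large group, gives in this assay an at least 6.8-fold lower number from compound 3 to compound 4 (0.83 log units; beyond the scatter), so a change of one heavy atom here is enough to produce a readable value. Moving from 3-bromophenyl to 4-fluorophenyl on the sulfonyl sulfur gives an at least 6.8-fold lower number from compound 2 to compound 4 (0.83 log units; beyond the scatter), though this change alters both the group and where it sits on the ring. Compounds 2 and 3 alone showed only a shared limit, whereas compound 4 shows that the group on the sulfonyl sulfur can take a compound off it: the limit of > 40000 nM in this assay, at which 2 of the 4 values shown sit.

As far as these compounds go, the true sizes of these steps stay unknown, and the step between the two limits cannot be read at all. From the compounds shown here alone, whether chloro, methoxy or an amine in the same place would behave like fluoro also remains open.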